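Chloro in place of hydrogen on compound 1

This account rests on a few compounds, and the source may have more. Where it says the series, first, only, none or still open, it means among the compounds named here.

Within the data shown here, in a functional assay on SW-620 cells (Homo sapiens) for antiproliferative activity, read by sulforhodamine B assay, with a stated time of 48 h (a higher number here means a weaker inhibitor, a lower number a stronger inhibitor), compound 1 `O=C(CCCCCCN1C(=O)/C(=N\O)c2ccccc21)NO` gives 640 nM and stands highest of the two numbers so far. Compound 2 `O=C(CCCCCCN1C(=O)/C(=N\O)c2cc(F)ccc21)NO` gives 110 nM in the same read-out. Compound 3 `O=C(CCCCCCN1C(=O)/C(=N\O)c2cc(Cl)ccc21)NO` is unmeasured and differs from compound 1 as follows: chloro in place of hydrogen on an aromatic carbon with chloro in place of hydrogen on an aromatic carbon. Among the measured compounds shown here, the one measured step bearing on it is a 5.8-fold lower number from compound 1 to compound 2 (0.76 log units; beyond the scatter) with fluoro in place of hydrogen, modest and beyond the scatter. A similar step toward a lower number is therefore expected in this assay from this single precedent. The estimated change is a 4.3-fold lower number from compound 1 to compound 3 (0.63 log units; beyond the scatter) in all. Compound 3 is expected at 150 nM within an estimated range of 50 nM to 450 nM for now.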

Compound 3, half-maximal inhibitory concentration: 650 nM
Estimate against measurement, compound 3: 4.3-fold (0.64 log units) below; the measured number lies above the stated range.
By their numbers in this assay, from the lowest: compound 2; then compounds 1 and 3 (each within the scatter of the next).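

At this aromatic carbon the identity of the halogen matters: chloro in place of hydrogen gives a 1.0-fold higher number from compound 1 to compound 3 (0.01 log units; within the scatter), while chloro in place of fluoro gives a 5.9-fold higher number from compound 2 to compound 3 (0.77 log units; beyond the scatter). In this assay, the lower number seen with fluoro therefore does not extend to chloro, and among these three compounds only compound 2 separates from the others. Nothing on hand accounts for the difference between fluoro and chloro here.

As far as these compounds go, it remains open whether bromo, methoxy or an amine at this carbon would track fluoro or chloro. Also open, from the compounds shown here alone, is whether fluoro on another aromatic carbon, or on a compound with a longer chain, would give a similar step.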